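This account rests on a few compounds, and the source may have more. Where it says the series, first, only, none or still open, it means among the compounds named here.

Compound 2 `CN(C)CCn1cnnc1-c1cc(Oc2ccc(NC(=O)N/N=C/c3ccc(O)c(F)c3)cc2F)ccn1` gives 3310 nM in a functional assay on HT-29 cells (Homo sapiens) for cytotoxicity, read by MTT assay, with a stated time of 72 h (a lower number here means a stronger inhibitor, a higher number a weaker inhibitor), the highest of the two numbers at hand; its nearest neighbour, compound 1 `CN(C)CCn1cnnc1-c1cc(Oc2ccc(NC(=O)N/N=C/c3ccc(F)cc3)cc2F)ccn1`, gives 1370 nM. Compound 3 `COc1ccc(/C=N/NC(=O)Nc2ccc(Oc3ccnc(-c4nncn4CCN(C)C)c3)c(F)c2)cc1O` differs from compound 2 by 3-hydroxy-4-methoxyphenyl in place of 3-fluoro-4-hydroxyphenyl on a carbon with a double bond to nitrogen. Among the compounds with values here, only one measured step touches the same ring: a 2.4-fold higher number from compound 1 to compound 2 (0.38 log units; beyond the scatter). That step exchanged a single substituent, whereas the change to compound 3 retains a hydroxy and adds a methoxy, so no step beyond the scatter is expected, with a slight lean toward a higher number, a 1.1-fold higher number from compound 2 to compound 3 (0.06 log units; within the scatter). Compound 3 is therefore estimated to give 3800 nM, in the range 1500 nM to 9500 nM.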

Compound 3, half-maximal inhibitory concentration: 960 nM
The estimate for compound 3 lay 4.0-fold (0.60 log units) above the measured number, outside the stated range (below it).
By their numbers in this assay, from the lowest: compounds 3 and 1 (each within the scatter of the next); then compound 2.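

On the carbon with a double bond to nitrogen, carrying a hydroxy does not by itself set the number in this assay: 3-hydroxy-4-methoxyphenyl in place of 3-fluoro-4-hydroxyphenyl gives a 3.4-fold lower number from compound 2 to compound 3 (0.54 log units; beyond the scatter) and so more than offsets the earlier rise. Against 4-fluorophenyl, the same ring gives a 1.4-fold lower number from compound 1 to compound 3 (0.15 log units; within the scatter) and no gain can be claimed. Nothing at hand explains why these rings differ. Still open, from the compounds shown here alone, is whether the methoxy or the hydroxy carries the drop, and how an ethoxy or an amine on this ring would read.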